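A few compounds are considered here, and "the series" means these few. Any claim that something is new, unique, unknown or untested is made for them only; others in the source may bear on it.

Measured compounds in an ADME assay on MT4 cells (Homo sapiens) for cytotoxicity, read by MTT assay, with a stated time of 5 days; a lower number here means that less compound is tolerated, a higher number that more compound is tolerated:

Compound 1 `Cc1ccc(NC(=O)CSc2snnc2-c2ccc(Br)cc2Br)c([N+](=O)[O-])c1`: > 229000 nM, a limit of this assay rather than a number.
Compound 2 `O=C(CSc1snnc1-c1ccc(Br)cc1Br)Nc1ccccc1`: 24800 nM.
Compound 3 `CC(=O)c1ccc(NC(=O)CSc2snnc2-c2ccc(Br)cc2Br)c(Br)c1`: > 206000 nM, again a limit of this assay rather than a number.

Among the measured compounds shown here, compound 2 stands as the only actual number in this assay; the two other results are limits. Compound 1 sits at the limit of > 229000 nM in this assay, at which 1 of the 3 values shown sits. Compound 3 sits at the limit of > 206000 nM in this assay, at which 1 of the 3 values shown sits. Of these pairs nothing more can be said than what the values show: compound 2 gives a number, the other two do not.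

Compound 4 `COC(=O)c1ccsc1NC(=O)CSc1snnc1-c1ccc(Br)cc1Br` is not yet measured. It differs from compound 2 by 3-(methoxycarbonyl)thiophen-2-yl in place of phenyl on an amide-type nitrogen. For the measured compounds named here, no measured pair isolates this change, so the size of the step in this assay cannot be read from the series. The expectation is a moderate step toward a more tolerated compound, beyond the scatter but not far, with a real chance that only a limit is returned. Compound 4 is estimated at 60000 nM, with a range from 15000 nM to 250000 nM. The step this estimate implies is expected to be a 2.4-fold higher number from compound 2 to compound 4 (0.38 log units; beyond the scatter).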

Compound 4, half-maximal cytotoxic concentration: > 227000 nM
Compound 4: only a limit was reported; the forecaster's own chance of this, stated with the estimate: 35%; middle value at least 3.7-fold (0.57 log units) from the limit.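

In this assay, among the compounds shown here, 3-(methoxycarbonyl)thiophen-2-yl in place of phenyl on an amide-type nitrogen gives an at least 9.1-fold higher number from compound 2 to compound 4 (0.96 log units; beyond the scatter), the only change at a single place that can be read. Compound 4 returns a limit rather than a number: the limit of > 227000 nM in this assay, at which 1 of the 4 values shown sits. This position therefore tolerates a change of ring and an added ester without moving the read-out toward less tolerated compounds, and the step has a lower bound only, with its true size unknown.

This single pair does not separate the change from a six-membered to a five-membered ring from the effect of the methoxycarbonyl group. From the compounds shown here alone, how a plain thiophen-2-yl, or a carboxylic acid in place of the methyl ester, would read in this assay remains open.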